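Adding an ethenyl link to compound 3

The source may report more compounds than this note shows. Statements on the series, on what has been measured and on what is new or still open speak of the compounds shown alone.

Of the compounds shown here, three with a shared core have been measured in a functional assay on EBC-1 cells (Homo sapiens) for antiproliferative activity, read by sulforhodamine B assay, with a stated time of 72 h; on this read-out lower numbers stand for stronger inhibition and higher numbers for weaker inhibition. Compound 1 `Cn1cc(-c2ccc(=O)n(CCOc3ccnc4cc(OCCCCC(=O)NO)ccc34)n2)cn1` gives 370 nM. Compound 2 `CC(=O)CCCCCOc1ccc2c(OCCn3nc(-c4cnn(C)c4)ccc3=O)ccnc2c1` gives 25 nM, and compound 3 `Cn1cc(-c2ccc(=O)n(CCOc3ccnc4cc(OCc5ccc(C(=O)Nc6ccccc6N)cc5)ccc34)n2)cn1` gives 42 nM. Compound 3 thus lies within the scatter of compound 2, and both lie beyond the scatter from compound 1.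

Compound 4 `Cn1cc(-c2ccc(=O)n(CCOc3ccnc4cc(OCc5ccc(/C=C/C(=O)Nc6ccccc6N)cc5)ccc34)n2)cn1` departs from compound 3 at one place: 2-((2-aminophenyl)carbamoyl)ethenyl in place of (2-aminophenyl)carbamoyl on an aromatic carbon. It has 2-((2-aminophenyl)carbamoyl)ethenyl in place of (2-aminophenyl)carbamoyl on an aromatic carbon, para to a large group.

Within the data shown here, only one measured step exists, and it does not cover this change. The large step of a 15-fold lower number from compound 1 to compound 2 (1.17 log units; beyond the scatter) swaps hydroxycarbamoyl for 2-oxopropyl, and neither group occurs in compound 3 or compound 4, so it offers no direct measure. It does show that one exchange among these compounds can move the number far, which argues for a wide range.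

With nothing pointing either way, no change beyond the scatter is expected in this assay, and the estimated step is a 1.1-fold higher number from compound 3 to compound 4 (0.03 log units; within the scatter). For compound 4 the estimated value is 45 nM, with an expected range from 15 nM to 135 nM.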

Compound 4, half-maximal inhibitory concentration: 490 nM
The estimate for compound 4 lay 11-fold (1.04 log units) below the measured number; the measured number lies above the stated range.
By their numbers in this assay, from the lowest: compounds 2 and 3 (each within the scatter of the next); then compounds 1 and 4 (each within the scatter of the next).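

In this assay, among these compounds, the change to 2-((2-aminophenyl)carbamoyl)ethenyl on this aromatic carbon, para to a large group, gives a 12-fold higher number from compound 3 to compound 4 (1.07 log units; beyond the scatter) and is the first measured change at this position. It shows that the position is not indifferent to the link that carries the (2-aminophenyl)carbamoyl group: the aromatic ring and the counts of hydrogen-bond donors and acceptors stay the same across the change, and the added ethenyl link alone separates the two compounds by more than the scatter. No measured evidence shown here accounts for the rise in the number.

The compounds shown leave open whether the rise belongs to the double bond or simply to the longer link, a question that a saturated ethane-1,2-diyl link on the same aromatic carbon would address. They also leave open whether the ethenyl link has the same effect when it carries a hydroxycarbamoyl group instead of the (2-aminophenyl)carbamoyl group.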